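A few compounds are considered here, and "the series" means these few. Any claim that something is new, unique, unknown or untested is made for them only; others in the source may bear on it.

In a functional assay on SK-OV-3 cells (Homo sapiens) for antiproliferative activity (a lower number here means a stronger inhibitor of growth, a higher number a weaker inhibitor of growth), compound 1 `c1ccc(-c2cc(-c3ccccn3)nc(-c3ccccn3)c2)cc1` gives 0.12 ug/mL and compound 3 `c1ccc(-c2cc(-c3ccco3)cc(-c3ccccn3)n2)nc1` gives 0.13 ug/mL. These two numbers lie within the scatter of each other. Compound 2 `c1ccc(-c2cc(-c3ccsc3)cc(-c3cccnc3)n2)nc1` is reported only as a limit, > 100 ug/mL. Compound 4 `c1ccc(-c2cc(-c3cccs3)cc(-c3ccccn3)n2)nc1` carries thiophen-2-yl in place of furan-2-yl on an aromatic carbon, opposite the ring nitrogen: thiophen-2-yl in place of furan-2-yl on an aromatic carbon. Going by the values given here, the one measured step that bears on this change is a 1.1-fold higher number from compound 1 to compound 3 (0.03 log units; within the scatter), where furan-2-yl took the place of phenyl at that same position and the number stayed within the scatter. On that single step, no shift beyond the scatter is expected in this assay. The expected step is a 1.2-fold higher number from compound 3 to compound 4 (0.06 log units; within the scatter). Compound 4 is estimated at 0.15 ug/mL, with an expected range of 0.05 ug/mL to 0.5 ug/mL.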

Compound 4, concentration for 50% growth inhibition: 0.12 ug/mL
Compound 4: the middle estimate sits 1.3-fold (0.10 log units) above what was measured; measured number inside the range.
By their numbers in this assay, from the lowest: compounds 1, 4 and 3 (each within the scatter of the next). At a limit, above all of these: compound 2.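

In this assay, placing thiophen-2-yl opposite the ring nitrogen gives a 1.1-fold lower number from compound 3 to compound 4 (0.03 log units; within the scatter) and, measured against phenyl at that place, no change at the digits printed from compound 1 to compound 4 (within the scatter). Phenyl, furan-2-yl and thiophen-2-yl thus all read alike at this position, so a sulfur-bearing five-membered aromatic ring serves here as the oxygen-bearing one did. Nothing shown gives a reason for this sameness. Going by these compounds, what remains open is whether it extends beyond aromatic rings: an amine, a carboxylic acid or a longer chain at this position could read quite differently.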